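Removing the acetyl from the oxygen-linked chain

The source may hold more compounds than are shown below. What is called first, only, known or untested is meant among the compounds shown, and "the series" means these compounds.

compound 1, `CC(=O)OC(C)n1cnc2c(S)nc(F)nc21`, > 500000 nM
compound 2, `CC(=O)OCCOn1cnc2c(S)nc(F)nc21`, 35000 nM
compound 3, `CC(O)n1cnc2c(S)nc(F)nc21`, > 500000 nM

Of the compounds shown here, three of the shared core have been measured in a functional assay on MOLT-4 cells (Homo sapiens) for inhibition; a lower number here means a stronger inhibitor, a higher number a weaker inhibitor. Compound 1 gives only a limit, > 500000 nM. Compound 3 likewise gives only a limit, > 500000 nM. Compound 2 alone gives a number, 35000 nM, and so stands apart from the other two, which both sit at the limit of > 500000 nM in this assay, at which 2 of the 3 values shown sit. The step that the two limits leave unreadable from compound 1 to compound 3 cannot be sized, since both its ends are limits.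

Compound 4, `OCCOn1cnc2c(S)nc(F)nc21`, remains to be measured. It differs from compound 3 by 2-hydroxyethoxy in place of 1-hydroxyethyl on an aromatic nitrogen. Within the data shown here, it stands to compound 2 as compound 3 stands to compound 1, namely hydrogen in place of acetyl on an oxygen on a saturated carbon, and the one measured step of that kind, from compound 1 to compound 3, is unreadable and gives no guide to size. What compound 2 shows is that the oxygen-linked chain on the aromatic nitrogen can yield a readable number where the carbon-linked chain of compound 3 does not. Compound 4 is therefore expected to fall near compound 2 rather than at the limit. The step of an at least 8.3-fold lower number from compound 3 to compound 4 (0.92 log units; beyond the scatter) is expected to lead out of the limit into the readable range. The estimate for compound 4 is 60000 nM, with a range from 10000 nM to 500000 nM.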

Compound 4, half-maximal inhibitory concentration: 164000 nM
Compound 4: middle estimate off by 2.7-fold (0.44 log units), on the low side; low and high end bracket the measured number.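

In this assay, 2-hydroxyethoxy in place of 1-hydroxyethyl on an aromatic nitrogen gives an at least 3.0-fold lower number from compound 3 to compound 4 (0.48 log units; beyond the scatter), which shows that the oxygen-linked chain yields a readable number even without the acetyl. Hydrogen in place of acetyl on an oxygen on a saturated carbon now has a readable size for the first time, with a 4.7-fold higher number from compound 2 to compound 4 (0.67 log units; beyond the scatter), so on this chain the acetyl-bearing compound 2 is the stronger inhibitor by a modest step. The same change cannot be read from compound 1 to compound 3, and the step from compound 3 to compound 4 has only a bound, as compound 3 is a limit: the limit of > 500000 nM in this assay, at which 2 of the 4 values shown sit.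

The compounds shown leave open whether the modest step seen on removing the acetyl would hold for another ester on the same oxygen, such as a propionyl or benzoyl group. They also leave open how a longer chain such as 3-hydroxypropoxy, or an amine or a carboxylic acid at the end of the oxygen-linked chain, would read in this assay.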